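The source may report more compounds than this note shows. Statements on the series, on what has been measured and on what is new or still open speak of the compounds shown alone.

In a functional assay on MDA-N cells (Homo sapiens) (on this read-out higher numbers stand for weaker inhibition of growth and lower numbers for stronger inhibition of growth), compound 1 `Cc1cc(C)c2c(O)cc(-c3ccc(Cl)cc3)nc2n1` gives 3630 nM and compound 2 `Oc1cc(-c2ccc(Cl)cc2)nc2ncccc12` gives 8320 nM. Compound 3 `Cc1ccnc2nc(-c3ccc(F)cc3)cc(O)c12` gives 3550 nM, the lowest number of the three, though it is within the scatter of compound 1 and beyond the scatter only against compound 2. Compound 4 `Cc1ccnc2nc(-c3ccc(Cl)cc3)cc(O)c12` is not yet measured. It differs from compound 3 by chloro in place of fluoro on an aromatic carbon, para to a large group (chloro in place of fluoro on an aromatic carbon). For the measured compounds named here, no measured pair shows this exchange on its own, so its size rests on expectation alone. The estimated 1.1-fold higher number from compound 3 to compound 4 (0.05 log units; within the scatter) is expected to stay within the scatter, with no firm direction. Compound 4 is expected at 4000 nM, with an estimated range of 1900 nM to 8500 nM.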

Compound 4, concentration for 50% growth inhibition: 1320 nM
The estimate for compound 4 lay 3.0-fold (0.48 log units) above the measured number; the measured number lies below the stated range.
By their numbers in this assay, from the lowest: compound 4; then compounds 3 and 1 (each within the scatter of the next); then compound 2.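

In this assay, chloro in place of fluoro on an aromatic carbon, para to a large group, gives a 2.7-fold lower number from compound 3 to compound 4 (0.43 log units; beyond the scatter), so this position responds to the exchange. With chloro in place, methyl in place of hydrogen on an aromatic carbon gives a 6.3-fold lower number from compound 2 to compound 4 (0.80 log units; beyond the scatter), and hydrogen in place of methyl on an aromatic carbon gives a 2.8-fold lower number from compound 1 to compound 4 (0.44 log units; beyond the scatter), so adding or removing one methyl from compound 4 each raises the number. Nothing at hand explains these steps. On these data alone, whether bromo or methoxy at the same position would go lower remains open, as does whether an amine or a longer chain could replace the methyl.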